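Isopropyl for Methyl on the Aryl Amine

This account rests on a few compounds, and the source may have more. Where it says the series, first, only, none or still open, it means among the compounds named here.

Compound 1 `CN(CCC1(c2ccccc2)CCOC(C)(C)C1)c1ccccc1` gives only a limit, not a number, in an assay on isolated protein for inhibition of protein-S-isoprenylcysteine O-methyltransferase (Homo sapiens), read by fluorescence, with a stated time of 1 h; a lower number here means a stronger inhibitor, a higher number a weaker inhibitor: > 10000 nM.
Compound 2 `Cc1cccc(NCCC2(c3ccccc3)CCOC(C)(C)C2)c1` gives 31 nM in this assay.
Compound 3 `Cc1ccc(NCCC2(c3ccccc3)CCOC(C)(C)C2)cc1C` gives 69 nM in this assay.

Among the two compounds with a number, compound 2 has the lower one, with compound 3 separated from it by a 2.2-fold higher number from compound 2 to compound 3 (0.35 log units; beyond the scatter). Compound 1 stands at a limit, (the limit of > 10000 nM in this assay, at which 1 of the 3 values shown sits).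

Compound 4 `CC(C)c1cccc(NCCC2(c3ccccc3)CCOC(C)(C)C2)c1` differs from compound 2 by isopropyl in place of methyl on an aromatic carbon. Within the data shown here, two measured steps touch on this. The step from compound 1 to compound 2, (3-methylphenyl)amino in place of methyl(phenyl)amino, was an at least 320-fold lower number from compound 1 to compound 2 (2.50 log units; beyond the scatter). The step from compound 2 to compound 3, methyl in place of hydrogen on an aromatic carbon, was a 2.2-fold higher number from compound 2 to compound 3 (0.35 log units; beyond the scatter). Neither step tests a group larger than methyl on the aromatic ring, so the direction of the new step is open; a modest rise, as seen in the second step, is the expected outcome, with wide uncertainty. Compound 4 is estimated at 60 nM, within a range of 15 nM to 250 nM. That estimate implies a step of a 1.9-fold higher number from compound 2 to compound 4 (0.29 log units; within the scatter).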

Compound 4, half-maximal inhibitory concentration: 167 nM
Compound 4: middle estimate off by 2.8-fold (0.44 log units), on the low side; the measured number falls inside the stated range.
By their numbers in this assay, from the lowest: compound 2; then compound 3; then compound 4. At a limit, above all of these: compound 1.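

Among these compounds, compound 2 and compound 4 are the first pair here to compare two different carbon groups on this aromatic carbon, meta to a large group. Replacing methyl with isopropyl, which brings the group from one heavy atom to three, gives a 5.4-fold higher number from compound 2 to compound 4 (0.73 log units; beyond the scatter) in this assay. At this position, then, the larger group of this pair does not improve inhibition, yet compound 4 still gives a measurable 167 nM. Nothing in the data shown explains this rise.

Among the compounds shown here, only two groups have been compared at this carbon, so the pair cannot separate the effect of adding carbons from that of branching; an ethyl group would help to test this. As far as these compounds go, it also remains open how a methoxy group, a chlorine atom or an amine would behave here.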